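The compounds below may be only part of what the source reports. "The series", "measured", "known", "first", "only" and "open" are said of these compounds alone.

In a functional assay on A549 cells (Homo sapiens) for inhibition, read by MTT assay, with a stated time of 48 h (on this read-out lower numbers stand for stronger inhibition and higher numbers for weaker inhibition), compound 1 (`Cn1c(/C=C2\SC(=O)N(CC(=O)N3CCOCC3)C2=O)nc2ccccc21`) gives 38500 nM, compound 2 (`CCn1c(/C=C2\SC(=O)N(CC(=O)Nc3cc(C(C)(C)C)on3)C2=O)nc2ccccc21`) gives 44800 nM and compound 3 (`CCn1c(/C=C2\SC(=O)N(CC(=O)N3CCCC3)C2=O)nc2ccccc21`) gives 31200 nM, so compound 3 stands within the scatter of both others. Compound 4 (`Cn1c(/C=C2\SC(=O)N(CC(=O)N3CCCC3)C2=O)nc2ccccc21`) differs from compound 3 by hydrogen in place of methyl on a saturated chain carbon bound to an aromatic nitrogen: ethyl to methyl, on an aromatic nitrogen. Within the data shown here, no measured pair isolates this change. Among the measured compounds shown here, the only measured step, a 1.4-fold lower number from compound 2 to compound 3 (0.16 log units; within the scatter), lies elsewhere, on a carbonyl carbon, and it is small. The methyl of compound 4 already occurs in compound 1, at 38500 nM, though with a different amide. No step beyond the scatter is therefore expected, and the estimated step is a 1.1-fold higher number from compound 3 to compound 4 (0.04 log units; within the scatter). Compound 4 is expected at 34000 nM, with an estimated range of 20000 nM to 58000 nM.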

Compound 4, half-maximal inhibitory concentration: > 50000 nM
Compound 4: no number, only a limit (the forecaster's own chance of this, stated with the estimate: 3%); at least 1.4-fold (0.16 log units) between middle value and limit.
By their numbers in this assay, from the lowest: compounds 3, 1 and 2 (each within the scatter of the next). At a limit, above all of these: compound 4.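

In this assay compound 4 yields only a limit, > 50000 nM, and not a number: the limit of > 50000 nM in this assay, at which 1 of the 4 values shown sits. Ethyl to methyl on an aromatic nitrogen gives an at least 1.6-fold higher number from compound 3 to compound 4 (0.20 log units; that floor lies within the scatter), and the amide change gives an at least 1.2-fold higher number from compound 1 to compound 4 (0.11 log units; that floor lies within the scatter). Both floors lie within the scatter, so neither change is shown to shift the read-out, yet the pairing of methyl with pyrrolidin-1-yl is the only one shown that ends at a limit. As far as these compounds go, how far compound 4 lies past its limit stays open, so the full size of both steps cannot be read. Also open, from the compounds shown here alone, is how a longer chain, such as propyl, would read on that aromatic nitrogen.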